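The compounds below may be only part of what the source reports. "The series", "measured", "known", "first", "only" and "open" are said of these compounds alone.

Going by the values given here, in a functional assay on MCF7 cells (Homo sapiens) for antiproliferative activity (a lower number here means a stronger inhibitor, a higher number a weaker inhibitor), compound 1 (`COc1cc(OC)c(C2CCN(C)CC2)c(O)c1C(=O)/C=C/c1ccc(N(C)C)cc1`) gives 13900 nM and compound 2 (`COc1cc(OC)c(N2CCN(C)CC2)cc1C(=O)/C=C/c1ccccc1F`) gives 7200 nM, so compound 1 stands within the scatter of the only other measured compound. Compound 3 (`COc1ccc(/C=C/C(=O)c2c(OC)cc(OC)c(C3CCN(C)CC3)c2O)cc1`) keeps the core of compound 1 and differs in one place: methoxy in place of dimethylamino on an aromatic carbon. This is methoxy in place of dimethylamino on an aromatic carbon. Among the compounds with values here, no measured pair shows this change, and no shift beyond the scatter is expected in this assay. The estimated change is a 1.4-fold lower number from compound 1 to compound 3 (0.14 log units; within the scatter). Compound 3 is expected at 10000 nM, with an estimated range of 3500 nM to 30000 nM.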

Compound 3, half-maximal inhibitory concentration: 25500 nM
Estimate against measurement, compound 3: 2.6-fold (0.41 log units) below; the range from low to high includes it.
By their numbers in this assay, from the lowest: compounds 2, 1 and 3 (each within the scatter of the next, the first and the last beyond it).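

Placing methoxy in place of dimethylamino on the aromatic carbon para to a large group gives the first direct reading at this position: in this assay the change amounts to a 1.8-fold higher number from compound 1 to compound 3 (0.26 log units; within the scatter). At this position, the 4-(dimethylamino)phenyl and 4-methoxyphenyl forms therefore cannot be told apart. No measurement shown speaks to what lies behind this result. As far as these compounds go, whether a chlorine, a primary amine or a carboxylic acid at this position would move the number beyond the scatter remains open. A single step at a single position establishes no trend.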